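Working notes: the step from compound 2 to compound 4

The compounds below may be only part of what the source reports. "The series", "measured", "known", "first", "only" and "open" are said of these compounds alone.

Of the compounds shown here, three have been measured so far in an ADME assay on NIH3T3 cells (Mus musculus) for cytotoxicity; on this read-out lower numbers stand for an effect already at smaller amounts and higher numbers for an effect only at larger amounts of compound. Compound 1 (`Cc1ccccc1Oc1cccc(Cn2ccnc2)c1`) gives 79300 nM. Compound 3 (`Cc1cc(Oc2cccc(Cn3cnc4ccccc43)c2)cc(C)c1Cl`) gives 40000 nM, and the values of compound 1 and compound 3 lie within the scatter of each other.

Compound 2 (`Cc1cc(Oc2cccc(Cn3cccn3)c2)cc(C)c1Cl`) reads > 100000 nM, which is a limit of the assay and not a number. Its standing in this assay is therefore known only as that limit.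

Compound 4 (`Cc1nnc(Cc2cccc(Oc3cc(C)c(Cl)c(C)c3)c2)o1`) has not yet been measured. It differs from compound 2 by one change: 5-methyl-1,3,4-oxadiazol-2-yl in place of 1H-pyrazol-1-yl on a saturated chain carbon bound to an aromatic carbon.

Going by the values given here, no measured pair differs in one place, so the expectation rests on the few values at hand. Among the compounds with values here, with compound 1 at 79300 nM and compound 3 at 40000 nM as the only numbers available, a modest move toward lower numbers in this assay is expected, possibly none beyond the scatter. The step expected is an at least 1.4-fold lower number from compound 2 to compound 4 (0.15 log units; that floor lies within the scatter). For compound 4 the estimate is 70000 nM, with an expected range from 30000 nM to 100000 nM.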

Compound 4, half-maximal effective concentration: 6200 nM
The estimate for compound 4 lay 11-fold (1.05 log units) above the measured number; the whole stated range lies above it.
By their numbers in this assay, from the lowest: compound 4; then compounds 3 and 1 (each within the scatter of the next). At a limit, above all of these: compound 2.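

Going by these compounds alone, on the saturated chain carbon bound to an aromatic carbon, 5-methyl-1,3,4-oxadiazol-2-yl in place of 1H-pyrazol-1-yl gives the only single-place step in this assay: an at least 16-fold lower number from compound 2 to compound 4 (1.20 log units; beyond the scatter). Compound 2 reads > 100000 nM, which is a limit of the assay and not a number, so the size of this step is a floor: the limit of > 100000 nM in this assay, at which 1 of the 4 values shown sits. With the rest of compound 2 held fixed, this one change brings compound 4 to 6200 nM, showing that the read-out depends on the group at this position, which compounds 1, 2 and 3, differing from one another in more than one place, could not show.

As far as these compounds go, whether the step follows the five-membered ring with three hetero atoms or the methyl on that ring remains open, as does whether the same change would give a comparable step on the core of compound 1. From the compounds shown here alone, how this position would read with a carboxylic acid or an amine in place of the ring is also open.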